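Lengthening the Alkoxy Chain: From Ethoxy to Isopropoxy

This account rests on a few compounds, and the source may have more. Where it says the series, first, only, none or still open, it means among the compounds named here.

Of the compounds shown here, three built on the same core have so far been measured in a functional assay on A549 cells (Homo sapiens) for cytotoxicity, with a stated time of 48 h; on this read-out higher numbers stand for weaker inhibition and lower numbers for stronger inhibition. Compound 1, `CCOc1ccc2oc(/C=C/[S+](C)[O-])cc(=O)c2c1`, gives 1500 nM and stands second highest of the three numbers. Compound 2, `C[S+]([O-])/C=C/c1cc(=O)c2ccccc2o1`, carries hydrogen where compound 1 carries ethoxy. Compound 2 gives 1900 nM; the step of a 1.3-fold higher number from compound 1 to compound 2 (0.10 log units; within the scatter) lies within the scatter. Compound 3, `CCCCOc1ccc2oc(/C=C/[S+](C)[O-])cc(=O)c2c1`, extends the chain further and gives 1400 nM, so that a 1.1-fold lower number from compound 1 to compound 3 (0.03 log units; within the scatter) and a 1.4-fold lower number from compound 2 to compound 3 (0.13 log units; within the scatter) also stay within the scatter. Across this small set, the alkoxy group has made no difference that can be distinguished from repeat variation.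

Compound 4, `CC(C)Oc1ccc2oc(/C=C/[S+](C)[O-])cc(=O)c2c1`, is the next step from compound 1. The change is methyl in place of hydrogen on a saturated chain carbon bound to an oxygen on an aromatic ring and a saturated chain carbon. Among the measured compounds shown here, the closest precedent is the step from compound 1 to compound 3, where adding ethyl on the same chain left this assay unchanged within the scatter, and removing the whole group in compound 2 likewise left it unchanged. On that basis no movement beyond the scatter is expected. Compound 4 is therefore estimated to give 1500 nM, with a range of 800 nM to 2800 nM, which amounts to an expected step of no change at the digits printed from compound 1 to compound 4 (within the scatter).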

Compound 4, half-maximal inhibitory concentration: 1500 nM
The estimate for compound 4 equals the measured number at the digits printed, and the stated range covers the measured number.
By their numbers in this assay, from the lowest: compounds 3, 1, 4 and 2 (each within the scatter of the next).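

Branching is what compound 4 adds, since the earlier compounds only lengthened the chain on the oxygen or removed the group: methyl on the saturated chain carbon bound to an oxygen on an aromatic ring gives in this assay no change at the digits printed from compound 1 to compound 4 (within the scatter) and so leaves the number where it was. The branched isopropoxy group also cannot be told apart from the unbranched chain, with a 1.1-fold higher number from compound 3 to compound 4 (0.03 log units; within the scatter), or from plain hydrogen, with a 1.3-fold lower number from compound 2 to compound 4 (0.10 log units; within the scatter), so hydrogen, ethoxy, butoxy and isopropoxy all sit within the scatter of one another here. No measurement at hand accounts for this flat result.

As far as these compounds go, all four groups at this place are hydrogen or a simple alkoxy chain, so it remains open whether an amine, a carboxylic acid or a much longer chain would move the number beyond the scatter. From the compounds shown here alone, it is equally open whether a change elsewhere on the shared core would do so, and this series alone cannot say which parts of the molecule matter for the effect on these cells.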